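Swapping a Chlorohydroxyphenyl for a Dimethylphenyl

This account rests on a few compounds, and the source may have more. Where it says the series, first, only, none or still open, it means among the compounds named here.

Measured so far:
compound 1 `Oc1cccc(C(Nc2ccccn2)c2ccc3cccnc3c2O)c1Cl` — 370 nM
compound 2 `CN(C)c1cccc(C(c2ccc(F)cc2)N2CCCCC2)c1O` — > 30000 nM

Of the compounds shown here, two have been tested in an assay for inhibition of protein disulfide-isomerase (Homo sapiens), with a stated time of 1 h; a higher number here means a weaker inhibitor, a lower number a stronger inhibitor. Among the measured compounds shown here, compound 1 gives 370 nM in this assay, and that is the only actual number available. Compound 2 gives > 30000 nM in this assay, which is a limit of the assay rather than a measured number. Compound 1 therefore stands alone as the single quantified inhibitor, with the other result being (the limit of > 30000 nM in this assay, at which 1 of the 2 values shown sits).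

Compound 3 `Cc1ccc(C)c(C(Nc2ccccn2)c2ccc3cccnc3c2O)c1` has not yet been measured. It differs from compound 1 in one place: 2,5-dimethylphenyl in place of 2-chloro-3-hydroxyphenyl on a saturated chain carbon bound to an aromatic carbon and a nitrogen on an aromatic ring. The leaving ring carries one hydrogen-bond donor and one hydrogen-bond acceptor; the entering ring carries none. For the measured compounds named here, no step between two measured compounds exists here, so the expectation rests on this structural change alone, without a comparable precedent.

The step from compound 1 to compound 3 is expected to be a 6.8-fold higher number from compound 1 to compound 3 (0.83 log units; beyond the scatter) in this assay, a loss of potency beyond the usual scatter. Compound 3 is expected to give about 2500 nM in this assay, with a plausible range from 600 nM to 12000 nM.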

Compound 3, half-maximal inhibitory concentration: 730 nM
Compound 3: middle estimate off by 3.4-fold (0.53 log units), on the high side; the measured number falls inside the stated range.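

In this assay, putting 2,5-dimethylphenyl in place of 2-chloro-3-hydroxyphenyl gives a 2.0-fold higher number from compound 1 to compound 3 (0.30 log units; within the scatter), so the two compounds cannot be told apart in this test. Among the compounds shown here, this is the first readable comparison at this position, on a saturated chain carbon bound to an aromatic carbon and a nitrogen on an aromatic ring, and it shows that inhibition in this range does not depend on the chlorine, the hydroxyl, or a hydrogen-bond donor or acceptor on this ring, since the entering ring carries neither a donor nor an acceptor. No measurement shown here bears on why the two rings perform alike.

From the compounds shown here alone, whether this tolerance extends to other groups stays open, for example a ring carrying a carboxylic acid or a primary amine, or a plain phenyl ring with no substituents at all. Compound 2 gives > 30000 nM, which is a limit of the assay, and it differs from compound 1 in more than one place, leaving open which of its changes matter.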